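The compounds below may be only part of what the source reports. "The series", "measured", "known", "first", "only" and "open" are said of these compounds alone.

Measured so far in a functional assay for inhibition, with Homo sapiens as the target; on this read-out lower numbers stand for stronger inhibition and higher numbers for weaker inhibition:
compound 1, `CCOC(=O)/C(=C\c1cccc(OCC(=O)O)c1)c1nc(-c2ccccc2)c(-c2ccccc2)o1`, gives 360 nM;
compound 2, `CCOC(=O)/C(=C\c1cccc(OCC(=O)O)c1OC)c1nc(-c2ccccc2)c(-c2ccccc2)o1`, gives 130 nM;
compound 3, `CCOC(=O)C(Cc1cccc(OCC(=O)O)c1)c1nc(-c2ccccc2)c(-c2ccccc2)o1`, gives 120 nM.

Compound 2 differs from compound 1 by one change: methoxy in place of hydrogen on an aromatic carbon. That change made a step of a 2.8-fold lower number from compound 1 to compound 2 (0.44 log units; beyond the scatter) in this assay. Compound 3 shares its side groups with compound 1 but has a different core; the difference between the two cores is not broken down here. What the numbers show is that compound 3 gives a lower number than compound 1, while the numbers of compound 2 and compound 3 lie within the usual scatter of each other, so no order can be read between them.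

Compound 4, `CCOC(=O)C(Cc1cccc(OCC(=O)O)c1OC)c1nc(-c2ccccc2)c(-c2ccccc2)o1`, is not yet measured. It differs from compound 3 by methoxy in place of hydrogen on an aromatic carbon, the same change that turned compound 1 into compound 2, at the same place in the ring. Because that change gave a 2.8-fold lower number from compound 1 to compound 2 (0.44 log units; beyond the scatter) in this assay, a step of similar size is expected from compound 3 to compound 4, though it rests on one example only and the number of compound 3 is already low, so a somewhat smaller gain is estimated: a 2.2-fold lower number from compound 3 to compound 4 (0.34 log units; beyond the scatter). For compound 4 the estimated value in this assay is 55 nM, expected to fall between 25 nM and 120 nM.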

Compound 4, half-maximal inhibitory concentration: 1180 nM
Estimate against measurement, compound 4: 21-fold (1.33 log units) below, and the stated range ends below it.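

On the second core, methoxy in place of hydrogen on an aromatic carbon gave a 9.8-fold higher number from compound 3 to compound 4 (0.99 log units; beyond the scatter) in this assay, so the change did not repeat what it did on the first core but went the opposite way. The two steps clearly differ: the same change on two cores in this assay, a 2.8-fold lower number (0.44 log units; beyond the scatter) from compound 1 to compound 2 and a 9.8-fold higher number (0.99 log units; beyond the scatter) from compound 3 to compound 4, 27-fold (1.44 log units) apart, beyond the scatter of two such steps

In this series, then, the outcome of this change depends on the core that carries it, and a result from one core cannot simply be transferred to the other. Within the data shown here, with only one pair on each core, however, this does not show why the two cores part ways, nor how the change would behave on any further core.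

The compounds shown leave open whether a methyl group or a fluorine atom on that same aromatic carbon would also give opposite results on the two cores. They also leave open whether the much weaker result of compound 4 would persist if an amide replaced its ethyl ester.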